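Pyrazole in Place of Furan on a Shared Nitrocatechol Core

The source may hold more compounds than are shown below. What is called first, only, known or untested is meant among the compounds shown, and "the series" means these compounds.

Three compounds with a shared core were tested in an assay on isolated protein for inhibition of Amine oxidase [flavin-containing] A (Homo sapiens), read by fluorescence; on this read-out lower numbers stand for stronger inhibition and higher numbers for weaker inhibition. Compound 1 `O=C(/C=C/c1ccoc1)c1cc(O)c(O)c([N+](=O)[O-])c1` gives 52900 nM in this assay. Compound 2 `N#Cc1ccc(/C=C/C(=O)c2cc(O)c(O)c([N+](=O)[O-])c2)cc1` gives 45300 nM, and compound 3 `CC(=O)N1N=C(c2cc(O)c(O)c([N+](=O)[O-])c2)CC1c1ccoc1` gives 90900 nM. Compound 1 therefore stands second highest of the three numbers, yet its gaps to compound 2 and to compound 3 both lie within the usual scatter, so no order among them can be read. Compound 4 `Cn1cc(/C=C/C(=O)c2cc(O)c(O)c([N+](=O)[O-])c2)cn1` differs from compound 1 by 1-methyl-1H-pyrazol-4-yl in place of furan-3-yl on a double-bonded chain carbon bound to a double-bonded chain carbon. Among the compounds with values here, no measured pair shows this change, so the expected step is a 1.1-fold higher number from compound 1 to compound 4 (0.05 log units; within the scatter), nothing beyond the scatter, leaning slightly toward weaker inhibition if anywhere. Compound 4 is expected to give about 60000 nM in this assay, with a range from 25000 nM to 150000 nM.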

Compound 4, half-maximal inhibitory concentration: 51500 nM
Estimate against measurement, compound 4: 1.2-fold (0.07 log units) above, and the stated range covers the measured number.
By their numbers in this assay, from the lowest: compounds 2, 4, 1 and 3 (each within the scatter of the next).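

Within the data shown here, the swap of furan-3-yl for 1-methyl-1H-pyrazol-4-yl on a double-bonded chain carbon bound to a double-bonded chain carbon gives the first direct reading at this position in this assay, namely a 1.0-fold lower number from compound 1 to compound 4 (0.01 log units; within the scatter). The two rings differ in hetero atoms and heavy atoms, yet the values of this pair cannot be told apart. Nothing in the data explains this result.

All the numbers shown lie within the scatter of their neighbours, so it stays open whether this position affects inhibition at all. On these data alone, how an amine or a carboxylic acid on the ring at this place would read also remains open.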